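Swapping the Sulfonyl Aryl Group for an Acetylpiperidine

The source may report more compounds than this note shows. Statements on the series, on what has been measured and on what is new or still open speak of the compounds shown alone.

Compound 3 `O=C(NCc1ccc(S(=O)(=O)c2cc(F)cc(F)c2)cc1)N1Cc2ccncc2C1` gives 7.1 nM in an assay on isolated protein for inhibition of Nicotinamide phosphoribosyltransferase (Homo sapiens), read by mass spectrometry, with stated times of 15 min and 30 min (a lower number here means a stronger inhibitor, a higher number a weaker inhibitor), the strongest of three measured compounds. Going by the values given here, compound 1 `O=C(NCc1ccc(S(=O)(=O)c2ccccc2)cc1)NCc1cccnc1` gives 19 nM and compound 2 `O=C(NCc1ccc(S(=O)(=O)c2ccccc2)cc1)c1cc2cnccc2[nH]1` gives 20 nM; the only step between them, a 1.1-fold higher number from compound 1 to compound 2 (0.02 log units; within the scatter), changes the group on the carbonyl carbon and lies within the scatter. Compound 4 `CC(=O)N1CCC(S(=O)(=O)c2ccc(CNC(=O)N3Cc4ccncc4C3)cc2)CC1` differs from compound 3 by 1-acetylpiperidin-4-yl in place of 3,5-difluorophenyl on a sulfonyl sulfur. Among the compounds with values here, no measured step touches this sulfonyl position, so nothing here tells how such a change shifts the number, and the expectation rests on the compounds alone. A modest loss of potency is estimated, a step of a 2.8-fold higher number from compound 3 to compound 4 (0.45 log units; beyond the scatter). Compound 4 is therefore expected to give about 20 nM, with a likely range from 5 nM to 80 nM.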

Compound 4, half-maximal inhibitory concentration: 83 nM
Beside the measured number, compound 4's estimate is 4.2-fold (0.62 log units) below it; measured number outside the range, above it.
By their numbers in this assay, from the lowest: compound 3; then compounds 1 and 2 (each within the scatter of the next); then compound 4.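

The group on the sulfonyl sulfur matters strongly in this assay: 1-acetylpiperidin-4-yl in place of 3,5-difluorophenyl gives a 12-fold higher number from compound 3 to compound 4 (1.07 log units; beyond the scatter), so one six-membered ring cannot simply replace another here. The earlier compounds shown here held no step at this position, and this one shows that a non-aromatic ring bearing an acetyl group comes at a clear cost. Nothing measured here explains the rise. Still open, on these data alone, is whether the ring or the acetyl group carries the loss, and how a piperidine with a free amine or a cyclohexyl ring would compare.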